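The source may hold more compounds than are shown below. What is called first, only, known or untested is meant among the compounds shown, and "the series" means these compounds.

Measured compounds, with their values in an assay on cell membranes for binding affinity to adenosine receptor A1 (Bos taurus), read by radioligand binding; on this read-out higher numbers stand for weaker inhibition and lower numbers for stronger inhibition:

compound 1 `c1ccc(Cn2nnc3c(NC4CCCCC4)ncnc32)cc1`: 121 nM
compound 2 `CC1CCCC(Nc2ncnc3c2nnn3Cc2ccccc2)C1`: 770 nM
compound 3 `CC(Nc1ncnc2c1nnn2Cc1ccccc1)c1ccccc1`: 438 nM

Compound 3 holds the second highest number of the three. It sits close to compound 2, with a 1.8-fold lower number from compound 2 to compound 3 (0.25 log units; within the scatter), and further from compound 1, with a 3.6-fold higher number from compound 1 to compound 3 (0.56 log units; beyond the scatter).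

Compound 4, `Nc1ccc(CNc2ncnc3c2nnn3Cc2ccccc2)cc1`, is not yet measured. Its change from compound 3 is 4-aminobenzyl in place of 1-phenylethyl on a nitrogen on an aromatic ring. Of the measured steps, only the two ending at compound 3 touch the same nitrogen: a 3.6-fold higher number from compound 1 to compound 3 (0.56 log units; beyond the scatter) and a 1.8-fold lower number from compound 2 to compound 3 (0.25 log units; within the scatter). Among the compounds with values here, neither involves a benzyl group or an amino group, so no measured step covers this change directly. Together with a 6.4-fold higher number from compound 1 to compound 2 (0.80 log units; beyond the scatter), they show that changes at this position have moved the number by modest amounts, and both replacements of cyclohexyl raised it. On that basis a further modest rise in this assay is expected rather than a fall, with wide uncertainty.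

For compound 4 the estimate is 1500 nM, with a range of 400 nM to 6000 nM. The expected step is a 3.4-fold higher number from compound 3 to compound 4 (0.53 log units; beyond the scatter).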

Compound 4, inhibition constant: 9500 nM
Compound 4: middle estimate off by 6.3-fold (0.80 log units), on the low side; the whole stated range lies below it.
By their numbers in this assay, from the lowest: compound 1; then compounds 3 and 2 (each within the scatter of the next); then compound 4.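

In this assay, within the data shown here, the substituent on this nitrogen can move the number much further than the earlier compounds showed: 4-aminobenzyl gives a 22-fold higher number from compound 3 to compound 4 (1.34 log units; beyond the scatter) and a 12-fold higher number from compound 2 to compound 4 (1.09 log units; beyond the scatter) and also a 79-fold higher number from compound 1 to compound 4 (1.89 log units; beyond the scatter) on the same core. All three steps are large, whereas the earlier changes in this substituent were modest or within the scatter, and 1-phenylethyl and 4-aminobenzyl have the same heavy-atom count, so that count does not separate compound 3 from compound 4. No measurement on hand accounts for this rise.

The compounds shown do not separate the contribution of the amino group from that of the benzyl group, since none carries an unsubstituted benzyl. Also open, from the compounds shown here alone, is how a 4-hydroxybenzyl or a 2-phenylethyl group on this nitrogen would compare.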